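The source may hold more compounds than are shown below. What is called first, only, known or untested is meant among the compounds shown, and "the series" means these compounds.

In an ADME assay on MT4 cells (Homo sapiens) for cytotoxicity, read by MTT assay, with a stated time of 4 days (on this read-out lower numbers stand for higher toxicity in this test and higher numbers for lower toxicity in this test), compound 2 `N#Cc1ccc(Nc2nc(Oc3ccc(F)cc3)c3ccccc3n2)cc1` reaches only the limit of the assay, > 351000 nM, so no number is known for it; this is the limit of > 351000 nM in this assay, at which 1 of the 3 values shown sits. Compound 1 `CCOc1cc(C#N)cc(OCC)c1Oc1nc(Nc2ccc(C#N)cc2)nc2ccccc12` gives 108000 nM in this assay, and compound 3 `CCCOc1cc(C#N)cc(OCC)c1Oc1nc(Nc2ccc(C#N)cc2)nc2ccccc12` gives 123000 nM. Within the data shown here, the one measured step, a 1.1-fold higher number from compound 1 to compound 3 (0.06 log units; within the scatter), is a small methyl addition and lies within the scatter. Compound 4 `Cc1cc(Br)cc(Br)c1Oc1nc(Nc2ccc(C#N)cc2)nc2ccccc12` differs from compound 2 by 2,4-dibromo-6-methylphenyl in place of 4-fluorophenyl on an oxygen on an aromatic ring. Among the measured compounds shown here, no measured step covers an exchange of this kind at this place, so the measured step bears on it only loosely. Compound 4 is expected to sit near the numbers of compound 1 and compound 3 rather than at the limit. Compound 4 is thus expected to show a step of an at least 3.1-fold lower number from compound 2 to compound 4 (0.50 log units; beyond the scatter). Compound 4 is estimated at 110000 nM, within 30000 nM to 351000 nM.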

Compound 4, half-maximal cytotoxic concentration: 150000 nM
For compound 4 the middle estimate is 1.4-fold (0.13 log units) below the measured one; measured number inside the range.
By their numbers in this assay, from the lowest: compounds 1, 3 and 4 (each within the scatter of the next). At a limit, above all of these: compound 2.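

In this assay, the exchange of 4-fluorophenyl for 2,4-dibromo-6-methylphenyl on the oxygen gives an at least 2.3-fold lower number from compound 2 to compound 4 (0.36 log units; beyond the scatter). This shows that a change at this place can move the number beyond the scatter, which the earlier methyl step a 1.1-fold higher number from compound 1 to compound 3 (0.06 log units; within the scatter) did not. Compound 2 stands at a limit and has no number, so the step has a known minimum but no known full size: the limit of > 351000 nM in this assay, at which 1 of the 4 values shown sits.

Which of the two bromines or the methyl carries the step remains open. So does what an amine or a carboxylic acid on this phenyl would give.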